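A few compounds are considered here, and "the series" means these few. Any claim that something is new, unique, unknown or untested is made for them only; others in the source may bear on it.

Notes on the series. Compound 1 `CC1=C(C(=O)Nc2ccccc2Cl)C(c2ccccc2Cl)NC(=S)N1` has been examined in an ADME assay on Vero cells (Chlorocebus sabaeus) for cytotoxicity, read by XTT assay, with a stated time of 72 h; a higher number here means that more compound is tolerated, a lower number that less compound is tolerated. For compound 1 the result is a limit of the assay, not a number, at > 100000 nM. Compound 2 `CC1=C(C(=O)Nc2ccccn2)C(c2cccs2)NC(=O)N1` has been examined in the same assay. For compound 2 the result is likewise a limit, not a number, at > 100000 nM. Going by the values given here, compound 2 therefore stands only at a limit in this assay, and the one further value shown is a limit as well, so that the limit of > 100000 nM in this assay, at which 2 of the 2 values shown sit, describes the whole of what has been measured.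

Compound 3 `CC1=C(C(=O)Nc2ccc(Cl)cc2)C(c2cccs2)NC(=O)N1` is not yet measured. It differs from compound 2 by 4-chlorophenyl in place of pyridin-2-yl on an amide-type nitrogen. Among the compounds with values here, no step between two measured compounds has been recorded, so the size of this change cannot be read from the series. With both measured compounds sitting at the same limit, the step from compound 2 to compound 3 is expected to be none beyond the scatter, a step that the limit leaves unreadable from compound 2 to compound 3. In this assay compound 3 is estimated at 150000 nM, within a range of 50000 nM to 450000 nM.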

Compound 3, half-maximal cytotoxic concentration: > 100000 nM
Compound 3 gave a limit, no number; the forecaster's own chance of this, stated with the estimate: 75%; the middle value does not contradict the limit.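

In this assay no step can be read from compound 2 to compound 3, whose results are both limits of the assay and not numbers. Open remains the half-maximal cytotoxic concentration of each compound, and with it whether 4-chlorophenyl in place of pyridin-2-yl on an amide-type nitrogen shifts that concentration at all; what stands so far is this: the limit of > 100000 nM in this assay, at which 3 of the 3 values shown sit.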